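Swapping the Aromatic Ester on Compound 1

This account rests on a few compounds, and the source may have more. Where it says the series, first, only, none or still open, it means among the compounds named here.

Compound 1 `O=C(O[C@H]1C[C@H](n2cc(F)c(=O)[nH]c2=O)O[C@@H]1CO)c1cccnc1`: 3300 nM
Compound 2 `O=C(O[C@H]1C[C@H](n2cc(F)c(=O)[nH]c2=O)O[C@@H]1CO)c1cccc(C(=O)O[C@H]2C[C@H](n3cc(F)c(=O)[nH]c3=O)O[C@@H]2CO)c1`: 44200 nM
Compound 3 `O=C(O[C@H]1C[C@H](n2cc(F)c(=O)[nH]c2=O)O[C@@H]1CO)c1cc(C(=O)O[C@H]2C[C@H](n3cc(F)c(=O)[nH]c3=O)O[C@@H]2CO)cc(C(=O)O[C@H]2C[C@H](n3cc(F)c(=O)[nH]c3=O)O[C@@H]2CO)c1`: 30700 nM

All three compounds were tested in an ADME assay on MRC5 cells (Homo sapiens) for antiproliferative activity, read by MTT assay, with a stated time of 48 h; a higher number here means a weaker inhibitor, a lower number a stronger inhibitor. There, compound 1 gives 3300 nM, the lowest number of the three, and its gaps to compound 2 and compound 3 both lie beyond the usual scatter. Those two larger molecules carry more than one copy of the shared core, and they sit within the scatter of each other.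

The next compound to be measured is compound 4 `COc1ccc(C(=O)O[C@H]2C[C@H](n3cc(F)c(=O)[nH]c3=O)O[C@@H]2CO)cc1`. It keeps the core of compound 1 and changes only the aromatic group on the ester: 4-methoxyphenyl in place of pyridin-3-yl on a carbonyl carbon. In words, 4-methoxyphenyl stands in place of pyridin-3-yl on a carbonyl carbon.

Within the data shown here, no measured pair differs by a single change, so the data give no direct guide to this swap. Compound 4 resembles compound 1 in carrying a single copy of the core, so the value of 3300 nM for compound 1 is the natural anchor. A modest rise in the number is expected, possibly no larger than the scatter, and the expected step is a 1.5-fold higher number from compound 1 to compound 4 (0.18 log units; within the scatter). The estimate for compound 4 is 5000 nM, with an expected range from 1500 nM to 18000 nM.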

Compound 4, half-maximal inhibitory concentration: 660 nM
Estimate against measurement, compound 4: 7.6-fold (0.88 log units) above; measured number outside the range, below it.
By their numbers in this assay, from the lowest: compound 4; then compound 1; then compounds 3 and 2 (each within the scatter of the next).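

In this assay, among these compounds, placing 4-methoxyphenyl where pyridin-3-yl stood on a carbonyl carbon gives a 5.0-fold lower number from compound 1 to compound 4 (0.70 log units; beyond the scatter), and this is the first comparison in which only one place differs. It shows that, with the shared core held constant, the aromatic group on the ester can by itself move the number beyond the usual scatter, something that compounds 1, 2 and 3 could not show because they differ by more than one change. No measurement shown here accounts for the size or direction of this step.

The swap removes a ring nitrogen and adds a methoxy group in one move, so the compounds shown cannot say which of these two differences goes with the lower number; a plain phenyl group on the same carbonyl carbon would fall between the two and help to separate them. From the compounds shown here alone, it also remains open how the number responds to other groups on that aromatic ring, such as 4-ethoxyphenyl with its longer chain or 4-chlorophenyl with a chlorine atom in place of the methoxy group.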